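Swapping Trifluoromethyl for Methoxy in a Shared Core

This account rests on a few compounds, and the source may have more. Where it says the series, first, only, none or still open, it means among the compounds named here.

Three compounds sharing one core were measured in a functional assay on MDA-MB-468 cells (Homo sapiens) for antiproliferative activity, read by MTT assay, with a stated time of 24 h; a lower number here means a stronger inhibitor, a higher number a weaker inhibitor. Compound 1 `CNC(=O)c1ccccc1Oc1nc(Nc2cccc(Br)c2)ncc1Br` gives 31900 nM. Compound 3 `CNC(=O)c1ccccc1Oc1nc(Nc2cccc(C(F)(F)F)c2)ncc1Br` gives 32800 nM, the higher of the two numbers, although the step of a 1.0-fold higher number from compound 1 to compound 3 (0.01 log units; within the scatter) lies within the scatter. Compound 2 `CNC(=O)c1ccccc1Oc1nc(Nc2ccc(Cl)cc2F)ncc1Br` reaches only the assay limit, > 50000 nM. Compound 4 `CNC(=O)c1ccccc1Oc1nc(Nc2cccc(OC)c2)ncc1Br` differs from compound 3 by methoxy in place of trifluoromethyl on an aromatic carbon. Among the compounds with values here, two measured steps bear on this: the step of a 1.0-fold higher number from compound 1 to compound 3 (0.01 log units; within the scatter), a single group exchanged on the same ring, stayed within the scatter, while the step of an at least 1.5-fold higher number from compound 1 to compound 2 (0.19 log units; that floor lies within the scatter), a larger change, ended at a limit (the limit of > 50000 nM in this assay, at which 1 of the 3 values shown sits). The step of a 1.1-fold higher number from compound 3 to compound 4 (0.03 log units; within the scatter) is therefore expected to lie within the scatter. Compound 4 is estimated at 35000 nM, between 15000 nM and 80000 nM.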

Compound 4, half-maximal inhibitory concentration: 17800 nM
For compound 4 the middle estimate is 2.0-fold (0.29 log units) above the measured one; the range from low to high includes it.
By their numbers in this assay, from the lowest: compounds 4, 1 and 3 (each within the scatter of the next). At a limit, above all of these: compound 2.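

Methoxy brings an oxygen to this aromatic carbon, yet the step of a 1.8-fold lower number from compound 3 to compound 4 (0.27 log units; within the scatter) and the step of a 1.8-fold lower number from compound 1 to compound 4 (0.25 log units; within the scatter) both stay within the scatter, so bromo, trifluoromethyl and methoxy cannot be told apart here. The one step beyond the scatter, an at least 2.8-fold lower number from compound 2 to compound 4 (0.44 log units; beyond the scatter), exchanges the whole aryl group on the nitrogen and gives only a floor: the limit of > 50000 nM in this assay, at which 1 of the 4 values shown sits.

From the compounds shown here alone, whether an amine, a carboxylic acid or a longer chain at this aromatic carbon would shift the number beyond the scatter stays open. So does the true value behind that limit.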